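Removing the methylpiperazine from compound 2

The compounds below may be only part of what the source reports. "The series", "measured", "known", "first", "only" and "open" are said of these compounds alone.

Three measured compounds share one core. Among the compounds with values here, compound 1 `C=CC(=O)N1CC[C@H](N2C(=O)N(Cc3ccccc3)Cc3cnc(Nc4ccc(N5CCN(C)CC5)cc4OC)nc32)C1` gives 24% in an ADME assay on the whole organism (strain Sprague-Dawley) for pharmacokinetics, with Rattus norvegicus as the target, read by LC-MS, at a dose of 25 mg/kg by the oral route (on this read-out lower numbers stand for lower oral bioavailability and higher numbers for higher oral bioavailability), and compound 3 `C=CC(=O)N1CC[C@H](N2C(=O)N(c3ccccc3)Cc3cnc(Nc4ccc(N5CCN(C)CC5)cc4OC)nc32)C1` gives 44%; the one single-point step measured, a number 20 percentage points higher from compound 1 to compound 3 (beyond the scatter), concerns only the group on the ring nitrogen. Compound 2 `C=CC(=O)N1CC[C@H](N2C(=O)N(c3ccccc3)Cc3cnc(Nc4cccc(N5CCN(C)CC5)c4)nc32)C1` gives 20%, the lowest of the three numbers, though its gap to compound 1 lies within the scatter. Compound 4 `C=CC(=O)N1CC[C@H](N2C(=O)N(c3ccccc3)Cc3cnc(Nc4ccccc4)nc32)C1` differs from compound 2 by hydrogen in place of 4-methylpiperazin-1-yl on an aromatic carbon. Within the data shown here, no measured step touches this position, so the data give no direct guide. Compound 4 is therefore expected to move by a number 6 percentage points higher from compound 2 to compound 4 (within the scatter), a change that may well stay within the scatter. Compound 4 is estimated at 26%, plausibly between 8% and 50%.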

Compound 4, oral bioavailability in the Rattus norvegicus assay: 44%
For compound 4 the middle estimate is 18 percentage points below the measured one; low and high end bracket the measured number.
By their numbers in the Rattus norvegicus assay, from the lowest: compounds 2 and 1 (each within the scatter of the next); then compounds 3 and 4 (each within the scatter of the next).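

In the Rattus norvegicus assay this position proves open to change: hydrogen in place of 4-methylpiperazin-1-yl on an aromatic carbon brings a number 24 percentage points higher from compound 2 to compound 4 (beyond the scatter) and shows that the group is not needed for oral bioavailability in this series. In a physicochemical assay for solubility, read by HPLC, in phosphate buffer, measured as thermodynamic solubility, with a stated time of 24 h, at pH 6.8 (a higher number here means a more soluble compound, a lower number a less soluble compound), the same change runs the opposite way with compound 2 at 714 ug/mL and compound 4 at 3.5 ug/mL so that the two read-outs pull apart here, and the 4-methylpiperazin-1-yl group is tied to the far higher solubility of compound 2: the measured solubility of compound 2, 714 ug/mL, and of compound 4, 3.5 ug/mL, a 200-fold lower number (2.31 log units; beyond the scatter). Still open, on these data alone, is whether a smaller amine on this carbon, such as dimethylamino or morpholine, would keep the solubility of compound 2 together with the oral bioavailability of compound 4.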